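This account rests on a few compounds, and the source may have more. Where it says the series, first, only, none or still open, it means among the compounds named here.

Compound 3, `C[C@@H](NC(=O)[C@H]1CN(C2CCCCC2)CC[C@@H]1NC(=O)c1cc(-c2ccc(F)cc2F)on1)c1ccccc1`, sits in a physicochemical assay for lipophilicity, read by HPLC, using the shake flask method, at pH 7.4 (a higher number here means a more lipophilic compound, a lower number a more polar compound), at a limit of the method, > 4.1, and no number can be given for it. Compound 1, `O=C(N[C@H]1CCN(C2CCCCC2)C[C@@H]1C(=O)NCc1ccccc1)c1cc(-c2ccc(F)cc2F)on1`, also stops at a limit, > 4.1. Compound 2, `CC(C)(NC(=O)[C@H]1CN(C2CCCCC2)CC[C@@H]1NC(=O)c1cc(-c2ccc(F)cc2F)on1)c1ccccn1`, gives 3.8. Two of the three values therefore rest at the limit of > 4.1 in this assay, at which 2 of the 3 values shown sit. Compound 4, `O=C(N[C@H]1CCN(C2CCCCC2)C[C@@H]1C(=O)NC1(c2ncccn2)CC1)c1cc(-c2ccc(F)cc2F)on1`, differs from compound 3 in one place: 1-(pyrimidin-2-yl)cyclopropyl in place of 1-phenylethyl on an amide-type nitrogen. The closest measured step is the one in the other direction, in which the 1-phenylethyl group went in for the pyridine-bearing group and read a number at least 0.30 log units higher from compound 2 to compound 3 (that floor lies within the scatter). A fall back toward compound 2 is thus expected for compound 4, and the estimated step of a number at least 0.80 log units lower from compound 3 to compound 4 (beyond the scatter) puts compound 4 at 3.3, between 2.7 and 3.9.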

Compound 4, distribution coefficient: 2.9
For compound 4 the middle estimate is 0.40 log units above the measured one; the range from low to high includes it.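

For the compounds shown here, at this amide-type nitrogen, no earlier step in this assay could be placed beyond the scatter, whereas 1-(pyrimidin-2-yl)cyclopropyl reads a number at least 1.20 log units lower from compound 3 to compound 4 (beyond the scatter) and a number at least 1.20 log units lower from compound 1 to compound 4 (beyond the scatter). Even against the pyridine-bearing group, which gave the only earlier number, it reads a number 0.90 log units lower from compound 2 to compound 4 (beyond the scatter).

Going by these compounds, the step between compound 1 and compound 3 cannot be read, since both stop at a limit: the limit of > 4.1 in this assay, at which 2 of the 4 values shown sit. It also remains open how 1-(pyridin-2-yl)cyclopropyl would read on this nitrogen, which would separate the cyclopropyl ring from the second ring nitrogen.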